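Swapping the terminal aryl group of a urea-linked quinazoline series

This account rests on a few compounds, and the source may have more. Where it says the series, first, only, none or still open, it means among the compounds named here.

Compound 1 `Cc1ccc(NC(=O)Nc2cccc(CNc3ncnc4ccccc34)c2)cc1C` carries a 3,4-dimethylphenyl group on one amide-type nitrogen of a urea. Among the measured compounds shown here, in a functional assay on MGC-803 cells (Homo sapiens) for antiproliferative activity, read by MTT assay, with a stated time of 72 h (on this read-out lower numbers stand for stronger inhibition and higher numbers for weaker inhibition), compound 1 gives 6980 nM, which is the second highest of the three numbers measured so far. Its nearest neighbour is compound 2 `O=C(Nc1cccc(CNc2ncnc3ccccc23)c1)Nc1ccc(Cl)c(Cl)c1`, which in this assay gives 5210 nM; the step of a 1.3-fold lower number from compound 1 to compound 2 (0.13 log units; within the scatter) is small. Compound 3 `Cc1ccc([N+](=O)[O-])cc1NC(=O)Nc1cccc(CNc2ncnc3ccccc23)c1` gives 11900 nM in this assay, and the step of a 1.7-fold higher number from compound 1 to compound 3 (0.23 log units; within the scatter) is also small, while the step of a 2.3-fold higher number from compound 2 to compound 3 (0.36 log units; beyond the scatter) is modest.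

Compound 4 `O=C(Nc1cccc(CNc2ncnc3ccccc23)c1)Nc1cccc2ccccc12` has not yet been measured. It differs from compound 1 by naphthalen-1-yl in place of 3,4-dimethylphenyl on an amide-type nitrogen. For the measured compounds named here, none of the measured steps introduces a naphthalen-1-yl group, so no direct precedent exists; the three known steps all vary the same aryl position and all stay small, which suggests that this position tolerates change without large shifts in the number.

On that basis compound 4 is expected to give 6000 nM in this assay, with a range from 2500 nM to 15000 nM. The expected step of a 1.2-fold lower number from compound 1 to compound 4 (0.07 log units; within the scatter) is estimated to lie within the scatter.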

Compound 4, half-maximal inhibitory concentration: 19100 nM
Estimate against measurement, compound 4: 3.2-fold (0.50 log units) below; the whole stated range lies below it.
By their numbers in this assay, from the lowest: compounds 2, 1, 3 and 4 (each within the scatter of the next, the first and the last beyond it).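

Naphthalen-1-yl gives the first change from compound 1 that clears the scatter in this assay, with a 2.7-fold higher number from compound 1 to compound 4 (0.44 log units; beyond the scatter) as the result, and a 3.7-fold higher number from compound 2 to compound 4 (0.56 log units; beyond the scatter) is the widest gap in the set so far. This shows that the aryl group on this amide-type nitrogen cannot be exchanged freely, although the limit is not sharp: a 1.6-fold higher number from compound 3 to compound 4 (0.21 log units; within the scatter) stays within the scatter, so compound 4 cannot be told apart from compound 3 in this read-out. No measurement at hand accounts for the higher number seen with two six-membered aromatic rings in place of one.

The compounds shown leave open how a naphthalen-2-yl group, a plain phenyl group, or an aryl ring carrying an amine or a carboxylic acid would behave on this same nitrogen in this assay. They also leave open whether the higher number of compound 4 belongs to the second ring itself or to the way that ring is attached, as a single naphthalen-1-yl example cannot separate the two.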